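An aryl swap on a weakly growth-inhibiting core

This account rests on a few compounds, and the source may have more. Where it says the series, first, only, none or still open, it means among the compounds named here.

Compound 1 `S=C(Nc1ccccc1)N1N=C(c2ccc(Cl)cc2)CC1c1ccc2c(c1)OCCO2` is reported in a functional assay on WM 266-4 cells (Homo sapiens) for antiproliferative activity, read by MTT assay, with a stated time of 48 h (a lower number here means a stronger inhibitor of growth, a higher number a weaker inhibitor of growth), only as a limit of the assay; in this assay compound 1 gives > 200000 nM. Compound 2 `CSc1ccc(C2=NN(C(=S)Nc3ccccc3)C(c3ccc4c(c3)OCCO4)C2)cc1` in this assay gives 197000 nM, the only number shown here. The step of an at least 1.0-fold lower number from compound 1 to compound 2 (0.00 log units; that floor lies within the scatter) lies within the scatter. Compound 3 `S=C(Nc1ccccc1)N1N=C(c2ccccc2Br)CC1c1ccc2c(c1)OCCO2` differs from compound 2 by 2-bromophenyl in place of 4-(methylsulfanyl)phenyl on a carbon with a double bond to nitrogen. Among the measured compounds shown here, no measured step touches this position or this group, and the single measured step is within the scatter, so compound 3 is expected to show a 1.0-fold higher number from compound 2 to compound 3 (0.01 log units; within the scatter), a change no larger than the scatter. Compound 3 is therefore estimated at 200000 nM, with a range from 60000 nM to 500000 nM.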

Compound 3, concentration for 50% growth inhibition: > 200000 nM
Compound 3: a limit, no number (the forecaster's own chance of this, stated with the estimate: 50%); the middle value lies on the limit itself.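

With 2-bromophenyl in place of 4-(methylsulfanyl)phenyl, the record shows an at least 1.0-fold higher number from compound 2 to compound 3 (0.00 log units; that floor lies within the scatter). A bromine-bearing aryl group on this carbon therefore gives no readable gain in growth inhibition in this assay, and the step between compound 1 and compound 3 joins two limits and cannot be read. The results at this position largely end at an assay limit: the limit of > 200000 nM in this assay, at which 2 of the 3 values shown sit.

On these data alone, what an amine or a carboxylic acid on this aryl ring, or a longer chain in its place, would do stays open. So does whether any change at this carbon can bring the number clearly away from that limit.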